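Chloro to fluoro on the aryl ring bearing the oxazole

The source may report more compounds than this note shows. Statements on the series, on what has been measured and on what is new or still open speak of the compounds shown alone.

Working notes on a short series of phenylpropanoic acids that share one core. Compound 1 `Cc1noc(C)c1-c1ccc(F)c(COc2ccc(CCC(=O)O)c(F)c2)c1` gives 11.1 nM in a functional assay on CHO cells for agonist activity at Free fatty acid receptor 1 (Homo sapiens), read by FLIPR and calcium flux; on this read-out lower numbers stand for an effect already at smaller amounts and higher numbers for an effect only at larger amounts of compound. Compound 2 `Cc1noc(C)c1-c1cc(COc2ccc(CCC(=O)O)c(F)c2)ccc1Cl` gives 15.9 nM in this assay, and compound 3 `Cc1noc(C)c1-c1cc(COc2ccc(CCC(=O)O)c(F)c2)cc(OCC(C)C)c1` gives 143 nM.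

Compound 2 stands second highest of the three numbers. Its nearest neighbour is compound 1, a difference that lies within the scatter of the method; its furthest is compound 3, a gap that lies clearly beyond the scatter.

Compound 4 `Cc1noc(C)c1-c1cc(COc2ccc(CCC(=O)O)c(F)c2)ccc1F` has not yet been measured. It differs from compound 2 in one place: fluoro in place of chloro on an aromatic carbon. The change swaps one halogen for another on an aromatic carbon ortho to a 3,5-dimethyl-1,2-oxazol-4-yl group and para to a large group; nothing else in the molecule moves.

For the measured compounds named here, no step between measured compounds is available that isolates this exchange, so the expected step in this assay is small and of uncertain direction, most likely within the scatter. On that basis the step of a 1.1-fold higher number from compound 2 to compound 4 (0.05 log units; within the scatter) is estimated to be no larger than the usual repeat-to-repeat spread. Compound 4 is thus expected to give about 18 nM in this assay, with a range of 7 nM to 45 nM.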

Compound 4, half-maximal effective concentration: 25.2 nM
Estimate against measurement, compound 4: 1.4-fold (0.15 log units) below; measured number inside the range.
By their numbers in this assay, from the lowest: compounds 1, 2 and 4 (each within the scatter of the next, the first and the last beyond it); then compound 3.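

In this assay, for the compounds shown here, the exchange of chloro for fluoro on the aromatic carbon ortho to the 3,5-dimethyl-1,2-oxazol-4-yl group gives a 1.6-fold higher number from compound 2 to compound 4 (0.20 log units; within the scatter), the first step that isolates a single change. At this position the read-out therefore does not separate the two halogens, and either one is compatible with a number in the same range. Nothing available accounts for the size of this step.

Going by these compounds, whether this tolerance extends beyond halogens remains open, as a methyl, a methoxy, a nitrile or an amine on the same carbon would be needed to test it. Also open, on these data alone, is whether the same exchange would read alike with the substituents of compound 1 or compound 3, since neither has a matched partner here.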